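The compounds below may be only part of what the source reports. "The series", "measured", "known", "first", "only" and "open" are said of these compounds alone.

Measured compounds in a functional assay on C6 cells (Rattus norvegicus) for cytotoxicity, read by MTT assay, with a stated time of 24 h, tested at 50 ug/mL; a lower number here means a stronger effect, a higher number a weaker effect of the compound at the concentration tested: compound 1 `Cn1nnnc1SCC(=O)N/N=c1/scc(-c2ccccc2)n1-c1ccccc1` gives 56.2%; compound 2 `Cc1nnc(SCC(=O)N/N=c2/scc(-c3ccc(F)cc3)n2-c2ccccc2)s1` gives 37.4%; compound 3 `Cn1cnnc1SCC(=O)N/N=c1/scc(-c2ccccc2)n1-c1ccccc1` gives 62.4%.

Compound 3 stands at the highest of the three numbers, meaning the weakest effect at the tested concentration, yet the gap to compound 1 lies within the scatter; only the gap to compound 2 lies beyond it. The step of a number 6.2 percentage points higher from compound 1 to compound 3 (within the scatter) replaced one five-membered heteroaromatic group on the sulfur with another and left the read-out within the scatter.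

Compound 4 `Cc1nnc(SCC(=O)N/N=c2/scc(-c3ccccc3)n2-c2ccccc2)s1` is the next step from compound 3: 5-methyl-1,3,4-thiadiazol-2-yl in place of 4-methyl-4H-1,2,4-triazol-3-yl on a sulfur. For the measured compounds named here, the one measured step that touches the group on this sulfur is the one from compound 1 to compound 3, and it was within the scatter, which on its own would argue for no change beyond the scatter. Compound 2, however, carries the same 5-methyl-1,3,4-thiadiazol-2-yl group as compound 4 while differing from it in another place, and compound 2 gives a number far lower than compound 3. Weighing both, a step downward of moderate size is expected, a number 17.4 percentage points lower from compound 3 to compound 4 (beyond the scatter). For compound 4 in this assay the estimate is 45%, with a range from 30% to 60%.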

Compound 4, a percentage reported as activity, at one concentration (the size of the read-out at that concentration, not a potency): 63.9%
Estimate against measurement, compound 4: 18.9 percentage points below; measured number above the stated range.
By their numbers in this assay, from the lowest: compound 2; then compounds 1, 3 and 4 (each within the scatter of the next).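

In this assay the group on the sulfur now looks exchangeable among the three five-membered rings shown: a number 1.5 percentage points higher from compound 3 to compound 4 (within the scatter) and a number 7.7 percentage points higher from compound 1 to compound 4 (within the scatter) both stay within the scatter, so 5-methyl-1,3,4-thiadiazol-2-yl reads like the other two rings in this series. For the compounds shown here, the one step beyond the scatter lies elsewhere, with hydrogen in place of fluoro on an aromatic carbon giving a number 26.5 percentage points higher from compound 2 to compound 4 (beyond the scatter), so the low number of compound 2 goes with the fluoro group and not with the group on the sulfur, which it shares with compound 4. Nothing measured in this set accounts for either outcome.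

On these data alone, the fluoro step rests on this single pair, so it remains open whether it recurs with 4-methyl-4H-1,2,4-triazol-3-yl or 1-methyl-1H-tetrazol-5-yl on the sulfur, or whether chloro or methoxy on that aromatic carbon would give a similar number. Also open, as far as these compounds go, is whether something other than these rings on the sulfur, such as a carboxylic acid or a longer chain, would stay at the same level.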